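The compounds below may be only part of what the source reports. "The series", "measured", "known", "first", "only" and "open" are said of these compounds alone.

Measured compounds:
Compound 1, `Cc1cc(S(N)(=O)=O)ccc1NC(=O)COc1ccc(F)cc1Oc1ccc2ccccc2c1`, in an ADME assay on C8166 cells (Homo sapiens) for cytotoxicity, read by MTT assay (a higher number here means that more compound is tolerated, a lower number that less compound is tolerated), gives 68600 nM.
Compound 2, `Cc1cc(S(N)(=O)=O)ccc1NC(=O)COc1ccc(Cl)cc1Oc1ccc2ccccc2c1`, in this assay gives 119000 nM.
Compound 3, `Cc1cc(S(N)(=O)=O)ccc1NC(=O)COc1ccc(F)cc1Oc1ccc2ccccc2c1C`, in this assay gives 56100 nM.

Compound 2 stands highest of these three numbers. Its nearest neighbour is compound 1, from which a 1.7-fold higher number from compound 1 to compound 2 (0.24 log units; within the scatter); the furthest is compound 3, whose step to compound 2 lies beyond the scatter. Compound 4, `Cc1cc(S(N)(=O)=O)ccc1NC(=O)COc1ccc(Cl)cc1Oc1cc2ccccc2cc1C`, differs from compound 2 by methyl in place of hydrogen on an aromatic carbon. One measured step is of the same kind, a methyl added on an aromatic carbon of the same ring system, although at a different carbon: a 1.2-fold lower number from compound 1 to compound 3 (0.09 log units; within the scatter). For the measured compounds named here, that step lay within the scatter, so no move beyond the scatter is expected in this assay from compound 2 to compound 4 either, and the single comparison available gives no direction. Compound 4 is therefore estimated at 100000 nM, with a range of 50000 nM to 200000 nM, which means an expected step of a 1.2-fold lower number from compound 2 to compound 4 (0.08 log units; within the scatter).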

Compound 4, half-maximal cytotoxic concentration: 76700 nM
The estimate for compound 4 lay 1.3-fold (0.12 log units) above the measured number; the range from low to high includes it.
By their numbers in this assay, from the lowest: compounds 3, 1, 4 and 2 (each within the scatter of the next, the first and the last beyond it).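

The step from naphthalen-2-yl to 3-methylnaphthalen-2-yl in this assay reads as a 1.6-fold lower number from compound 2 to compound 4 (0.19 log units; within the scatter) and so adds a second carbon of this ring system, ortho to a large group, at which a methyl in place of hydrogen does not move the number beyond the scatter. No direction can be claimed for the methyl at either carbon, as neither step leaves the scatter. The change now stands on two cores, and the two steps do not differ beyond what such steps scatter by: the same change on two cores in this assay, a 1.2-fold lower number (0.09 log units; within the scatter) from compound 1 to compound 3 and a 1.6-fold lower number (0.19 log units; within the scatter) from compound 2 to compound 4, 1.3-fold (0.10 log units) apart, within the scatter of two such steps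

Going by these compounds, whether an ethyl, a methoxy or an amine at this carbon would move the number beyond the scatter remains open. Also open, on these data alone, is whether this same methyl would give a comparable step with fluoro in place of chloro.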